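Notes on a hydroxy to methoxy step

The source may hold more compounds than are shown below. What is called first, only, known or untested is meant among the compounds shown, and "the series" means these compounds.

- compound 1 `COc1ccc(C[C@H]2COC(=O)[C@@H]2Cc2ccc(Cl)c(Cl)c2)cc1` measured at 37000 nM
- compound 2 `COc1cc(C[C@H]2COC(=O)[C@@H]2Cc2ccc(Cl)c(Cl)c2)ccc1O` measured at 36000 nM

Both numbers come from a functional assay on HL-60 cells (Homo sapiens) for cytotoxicity, read by WST assay, with a stated time of 48 h (a lower number here means that less compound is needed, a higher number that more compound is needed for the effect), and lie within the scatter of each other, so compound 2 at 36000 nM stands level with compound 1 at 37000 nM on this read-out. The step to compound 3 `COc1ccc(C[C@H]2COC(=O)[C@@H]2Cc2ccc(Cl)c(Cl)c2)cc1OC` is methyl in place of hydrogen on an oxygen on an aromatic ring and reads as methyl in place of hydrogen on an oxygen on an aromatic ring, hydroxy to methoxy. In this assay, within the data shown here, no measured step yet shows what such a change does. Among the measured compounds shown here, no shift beyond the scatter is expected in either direction, with compound 2 at 36000 nM as the only anchor for the number. The estimated step is a 1.1-fold lower number from compound 2 to compound 3 (0.05 log units; within the scatter) and stays within the scatter. For compound 3 the expected value is 32000 nM with an estimated range from 14000 nM to 70000 nM around it.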

Compound 3, half-maximal effective concentration: 24000 nM
Compound 3: middle estimate off by 1.3-fold (0.12 log units), on the high side; measured number inside the range.
By their numbers in this assay, from the lowest: compounds 3, 2 and 1 (each within the scatter of the next).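

In this assay the series now has its first measured step for hydroxy to methoxy, on an oxygen on an aromatic ring (a 1.5-fold lower number from compound 2 to compound 3 (0.18 log units; within the scatter)), and this change stays within the scatter. The step of methoxy in place of hydrogen on an aromatic carbon (a 1.5-fold lower number from compound 1 to compound 3 (0.19 log units; within the scatter)) also stays within the scatter, so neither single change on this ring separates the compounds on this read-out. Nothing measured here on the compounds themselves offers an explanation for these small steps.

Still open, going by these compounds, is whether a longer chain on that oxygen, or an amine or a carboxylic acid in place of the methoxy, would move the number beyond the scatter. Also open, on these data alone, is what a change elsewhere on the shared core would do.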